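Clearance notes: from compound 1 to compound 3

This account rests on a few compounds, and the source may have more. Where it says the series, first, only, none or still open, it means among the compounds named here.

Going by the values given here, the series so far rests on two measurements in an ADME assay on liver for metabolic stability, with Liver microsome (Homo sapiens) as the target, using microsomes and NADPH, with a stated time of 30 min, tested at 0.5 uM; on this read-out higher numbers stand for fast clearance and lower numbers for slow clearance. Among the compounds with values here, compound 1 `O=c1[nH]ccn1CCOc1nn(-c2ccccc2F)c2ccc(F)cc12` gives 200 mL/min/kg, the only actual number available. Compound 2 `O=C1N(Cc2ncco2)CCN1c1cccc2c1cnn2-c1ccccc1F` gives < 33.4 mL/min/kg, which is a limit of the assay and not a number. Compound 1 therefore stands on the fast-clearance side of that limit.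

Compound 3 `O=C(COc1nn(-c2ccccc2F)c2ccc(F)cc12)N1CCOCC1` keeps the core of compound 1 and changes one place, on a saturated chain carbon bound to an oxygen on an aromatic ring. There, (morpholin-4-yl)carbonyl stands in place of a group with one five-membered aromatic ring with 2 hetero atoms (a group of 8 heavy atoms (5 carbon, 1 nitrogen, 2 oxygen; one six-membered non-aromatic ring with 2 hetero atoms) in place of a group of 7 heavy atoms (4 carbon, 2 nitrogen, 1 oxygen; one five-membered aromatic ring with 2 hetero atoms), on a saturated chain carbon bound to an oxygen on an aromatic ring).

Within the data shown here, no two measured compounds differ in one place only, so this step has no direct precedent. The expectation rests on compound 1 at 200 mL/min/kg, which leaves ample room for a fall and little for a rise. A moderate fall in this assay is expected, estimated as a 2.2-fold lower number from compound 1 to compound 3 (0.35 log units; beyond the scatter), though a result within the scatter remains possible. For compound 3 the estimated clearance is 90 mL/min/kg, with an expected range of 35 mL/min/kg to 190 mL/min/kg.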

Compound 3, clearance: 117 mL/min/kg
Compound 3: the middle estimate sits 1.3-fold (0.11 log units) below what was measured, within the range that was stated.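

Going by these compounds alone, this is the first step that can be read at a single place, on a saturated chain carbon bound to an oxygen on an aromatic ring. In this assay, putting (morpholin-4-yl)carbonyl in place of the group with the five-membered aromatic ring gives a 1.7-fold lower number from compound 1 to compound 3 (0.23 log units; within the scatter), so this exchange, which also takes the count of hydrogen-bond donors in the group from 1 to 0, does not separate the two compounds on clearance. Compound 2 alone stands at a limit of the assay and not at a number, and neither compound of this step reaches it: the limit of < 33.4 mL/min/kg in this assay, at which 1 of the 3 values shown sits.

Going by these compounds, whether any group at this place can shift clearance beyond the scatter stays open: a carboxylic acid, an amine or a longer chain on the same saturated chain carbon would test that, and a dimethylamide would show whether the morpholine ring matters to the result. Compound 2 differs from compound 1 and compound 3 in more than one place, so the compounds shown do not tell which part of its structure goes with its limit.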